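Swapping the amine substituent on the shared core

The compounds below may be only part of what the source reports. "The series", "measured", "known", "first", "only" and "open" are said of these compounds alone.

Measured compounds:
- Compound 1, `CC(C(=O)NCc1ccc(C(F)(F)F)nc1)c1ccc(NS(C)(=O)=O)c(F)c1`: "not active" (no number reported)
- Compound 2, `CC1CCC(Nc2nc(C(F)(F)F)ccc2CNC(=O)C(C)c2ccc(NS(C)(=O)=O)c(F)c2)CC1`: 1130 nM
- Compound 3, `CC(C(=O)NCc1ccc(C(F)(F)F)nc1N(C)C)c1ccc(NS(C)(=O)=O)c(F)c1`: 2390 nM

Compound 1 carries no substituent at the position in question, and in a functional assay on CHO-K1 cells for antagonist activity at transient receptor potential cation channel subfamily V member 1 (Homo sapiens), read by FLIPR (a higher number here means a weaker inhibitor, a lower number a stronger inhibitor), compound 1 gives "not active" (no number reported). Of the two compounds with a number in this assay, compound 2 has the lower one; its nearest neighbour is compound 3, and the step of a 2.1-fold higher number from compound 2 to compound 3 (0.33 log units; beyond the scatter) is modest.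

Compound 4, `CC(C(=O)NCc1ccc(C(F)(F)F)nc1N(C)c1ccccc1)c1ccc(NS(C)(=O)=O)c(F)c1`, has not been measured. It differs from compound 2 in one place: methyl(phenyl)amino in place of (4-methylcyclohexyl)amino on an aromatic carbon. Within the data shown here, the only measured step that touches this position is the one from compound 2 to compound 3, where the ring-bearing amine was cut back to a small one and the number rose modestly. Compound 4 keeps a six-membered ring on that nitrogen, so the expected change is smaller than that: none beyond the scatter, or a slight rise.

The estimate for compound 4 in this assay is therefore 1500 nM, within 600 nM to 4000 nM, an expected step of a 1.3-fold higher number from compound 2 to compound 4 (0.12 log units; within the scatter).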

Compound 4, half-maximal inhibitory concentration: 57.4 nM
The estimate for compound 4 lay 26-fold (1.42 log units) above the measured number, and the stated range ends above it.
By their numbers in this assay, from the lowest: compound 4; then compound 2; then compound 3.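

In this assay, among these compounds, the earlier compounds showed only a modest spread at this position, next to the ring nitrogen, but methyl(phenyl)amino in place of (4-methylcyclohexyl)amino gives a 20-fold lower number from compound 2 to compound 4 (1.29 log units; beyond the scatter) and makes clear that the group here can strongly change the reading. Replacing only one methyl on that nitrogen with phenyl gives a 42-fold lower number from compound 3 to compound 4 (1.62 log units; beyond the scatter), the largest step in this set. A six-membered ring on the nitrogen is not sufficient for a low number, as compound 2 has one too, with the same count of heavy atoms, but its ring is non-aromatic and its nitrogen keeps a hydrogen-bond donor.

As far as these compounds go, whether the aromatic ring or the missing donor matters more stays open, and phenylamino, which pairs that ring with a donor, could separate the two. Nothing shown here explains the drop in the number.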